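The source may hold more compounds than are shown below. What is called first, only, known or untested is meant among the compounds shown, and "the series" means these compounds.

Of the compounds shown here, two have been measured in an ADME assay for permeability, using PAMPA, with a stated time of 30 min, at pH 7.4 (on this read-out higher numbers stand for higher permeability and lower numbers for lower permeability), so far. Compound 1 `COc1ccc(Oc2ccc3c(NCCCNCc4cccc(OC)c4O)ccnc3c2)cc1` gives 317 10^-6 cm/s in this assay. Compound 2 `COc1ccc(F)cc1CNCCCNc1ccnc2cc(CCc3ccccc3)ccc12` gives 23 10^-6 cm/s in this assay, the lower of the two numbers, and the gap between compound 2 and compound 1 is larger than the usual scatter of repeated measurements. For the measured compounds named here, no pair of measured compounds differs in only one place, so no single structural step has yet been tied to a change in this assay.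

The next compound, compound 3 `COc1ccc(F)cc1CNCCCNc1ccnc2cc(Cc3ccc(C#N)cc3)ccc12`, differs from compound 2 in one place: 4-cyanophenyl in place of benzyl on a saturated chain carbon bound to an aromatic carbon. Going by the values given here, with no measured step of this kind to lean on, the expectation for compound 3 rests on the value of compound 2 alone. The step of a 1.5-fold lower number from compound 2 to compound 3 (0.19 log units; within the scatter) is expected to be small, most likely a modest drop that stays within the scatter. Compound 3 is therefore estimated at 15 10^-6 cm/s, with a likely range from 5 10^-6 cm/s to 40 10^-6 cm/s.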

Compound 3, apparent permeability: 23 10^-6 cm/s
Estimate against measurement, compound 3: 1.5-fold (0.19 log units) below; the range from low to high includes it.
By their numbers in this assay, from the lowest: compounds 2 and 3 (each within the scatter of the next); then compound 1.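

For the compounds shown here, this is the first step in this assay that changes a single place, and it reads no change at the digits printed from compound 2 to compound 3 (within the scatter) with the nitrile of 4-cyanophenyl now present. On a saturated chain carbon bound to an aromatic carbon, benzyl can therefore be exchanged for 4-cyanophenyl without a change beyond the scatter, so this place accepts at least one group that carries a nitrile. No measurement shown here accounts for this result.

Going by these compounds, whether this place accepts other groups as well, such as an amine, a carboxylic acid or a longer chain, remains open. On these data alone, compound 1 differs from compound 2 and compound 3 in more than one place, and which of its structural differences goes with its higher number also remains open.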